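Chloro for methyl on the compound 1 aryl group

The compounds below may be only part of what the source reports. "The series", "measured", "known", "first", "only" and "open" are said of these compounds alone.

- compound 1 `Cc1cc(C(F)(F)F)ccc1-c1cc2cnn([C@@H](CC(C)C)c3ccc(C(=O)NCCC(=O)O)cc3)c2cc1C` has a half-life of 3.1 h
- compound 2 `Cc1cc(C(F)(F)F)ccc1-c1cc2cn([C@@H](CC(C)C)c3ccc(C(=O)NCCC(=O)O)cc3)nc2cc1C` has a half-life of 4.3 h

Both half-lives were measured in an ADME assay on the whole organism (Rattus norvegicus, strain Sprague-Dawley) for metabolic stability, at a dose of 10 mg/kg by the oral route; a higher number here means that the compound lasts longer, a lower number that the compound disappears faster. Within the data shown here, compound 1 and compound 2 lie within the usual scatter of each other, so compound 1 stands level with the only other measured compound.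

The next compound to be measured is compound 3 `Cc1cc2c(cnn2[C@@H](CC(C)C)c2ccc(C(=O)NCCC(=O)O)cc2)cc1-c1ccc(C(F)(F)F)cc1Cl`, which differs from compound 1 in one place: chloro in place of methyl on an aromatic carbon. The exchange lies ortho to a large group and meta to a trifluoromethyl group, turning 2-methyl-4-(trifluoromethyl)phenyl into 2-chloro-4-(trifluoromethyl)phenyl.

Among the measured compounds shown here, no measured pair shows this exchange, so the data offer no direct guide to its effect. In this assay no step beyond the scatter is expected, and the expectation therefore stays close to compound 1 at 3.1 h. The expected step is a 1.1-fold higher number from compound 1 to compound 3 (0.04 log units; within the scatter). For compound 3 the estimated half-life is 3.4 h, with an expected range from 1.8 h to 6.5 h.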

Compound 3, half-life: 7.1 h
Compound 3: middle estimate off by 2.1-fold (0.32 log units), on the low side; the measured number lies above the stated range.
By their numbers in this assay, from the lowest: compounds 1, 2 and 3 (each within the scatter of the next, the first and the last beyond it).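

In this assay, replacing methyl with chloro on the 2-methyl-4-(trifluoromethyl)phenyl group gives a 2.3-fold higher number from compound 1 to compound 3 (0.36 log units; beyond the scatter). The earlier compounds shown here offered no step at this aromatic carbon, ortho to a large group and meta to a trifluoromethyl group, and this pair shows that the half-life can respond to an exchange made here. The change is small in what can be counted: one heavy atom leaves and one enters, with no ring, hydrogen-bond donor, hydrogen-bond acceptor or net charge on either side, and nothing available explains the step.

With only one exchange shown at this position, it remains open whether a hydrogen, fluoro, bromo, methoxy or nitrile group in place of the chloro would keep, extend or reverse the step. As far as these compounds go, it also remains open whether the same exchange of methyl for chloro on the aryl group of compound 2 would give a step of similar size, and whether any such step would hold at another dose or by another route.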